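Tetrabromobenzotriazole alcohols: adding a chloro group

A few compounds are considered here, and "the series" means these few. Any claim that something is new, unique, unknown or untested is made for them only; others in the source may bear on it.

Measured compounds:
compound 1 `OCC(O)Cn1nc2c(Br)c(Br)c(Br)c(Br)c2n1`: 89%
compound 2 `OC(CCn1nc2c(Br)c(Br)c(Br)c(Br)c2n1)c1ccc(Br)cc1`: 109%
compound 3 `OC(CCn1nc2c(Br)c(Br)c(Br)c(Br)c2n1)c1ccccc1`: 123%

In a functional assay on CCRF-CEM cells (Homo sapiens) for antiproliferative activity, read by MTT assay, with a stated time of 24 h, tested at 25 uM (on this read-out higher numbers stand for a weaker effect at the one concentration tested and lower numbers for a stronger effect), compound 3 gives 123%, the highest of the three numbers. Compound 2 comes nearest with 109%, and compound 1, which carries the diol side chain instead of the aryl-bearing one, lies furthest with 89%. For the measured compounds named here, the only step between neighbours differing in one place is the one where hydrogen replaces bromo on an aromatic carbon: a number 14 percentage points higher from compound 2 to compound 3 (beyond the scatter).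

Compound 4 `OC(CCn1nc2c(Br)c(Br)c(Br)c(Br)c2n1)c1cccc(Cl)c1` differs from compound 3 as follows: chloro in place of hydrogen on an aromatic carbon. Going by the values given here, this change is the reverse in kind of the one measured step, a halogen entering the phenyl ring rather than leaving it, though chloro rather than bromo and at a different place on the ring. Because a number 14 percentage points higher from compound 2 to compound 3 (beyond the scatter) was modest but beyond the scatter, a step of similar size in the opposite direction is expected in this assay, that is a somewhat lower number for compound 4, while a result within the scatter of compound 3 cannot be excluded. The expected step is a number 11 percentage points lower from compound 3 to compound 4 (beyond the scatter). Compound 4 is therefore estimated at 112%, with a range from 95% to 130%.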

Compound 4, a percentage reported as activity, at one concentration (the size of the read-out at that concentration, not a potency): 118%
Beside the measured number, compound 4's estimate is 6 percentage points below it; the range from low to high includes it.
By their numbers in this assay, from the lowest: compound 1; then compounds 2, 4 and 3 (each within the scatter of the next, the first and the last beyond it).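

In this assay, chloro in place of hydrogen at this place on the phenyl ring, meta to a large group, gives a number 5 percentage points lower from compound 3 to compound 4 (within the scatter), so this change does not separate compound 4 from compound 3, whereas the halogen change already seen, at a different place and with bromo, gave a number 14 percentage points higher from compound 2 to compound 3 (beyond the scatter). The exchange of 4-bromophenyl for 3-chlorophenyl gives a number 9 percentage points higher from compound 2 to compound 4 (within the scatter), so compound 4 is not separated from compound 2 either, and it sits within the scatter of two compounds that are themselves told apart. No measurement at hand bears on the reason for these numbers.

Still open, on these data alone, is whether any substituent on this phenyl ring can move the number beyond the scatter in the direction of a stronger effect, since a single chloro group at this place does not show it, and how an amine or a carboxylic acid at the same place would read in this assay. Also open, as far as these compounds go, is what a longer chain between the shared core and the alcohol carbon would do, with the phenyl ring left unchanged.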